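This account rests on a few compounds, and the source may have more. Where it says the series, first, only, none or still open, it means among the compounds named here.

Working notes on the series. Of the compounds shown here, three have been measured in a functional assay on A-375 cells (Homo sapiens) for antiproliferative activity, read by MTT assay, with a stated time of 48 h; on this read-out lower numbers stand for stronger inhibition and higher numbers for weaker inhibition. Compound 1 `CCCCCCCc1nc(N)n(CC(=O)Nc2ccccc2)c1-c1ccccc1Br` gives 9200 nM. Compound 2 `CCCCCc1nc(N)n(CC(=O)Nc2ccc(C)cc2)c1-c1ccccc1Br` gives 4300 nM. Compound 3 `CCCCCCCc1nc(N)n(CC(=O)Nc2ccc(C)cc2)c1-c1ccccc1Br` gives 5200 nM. Compound 3 stands within the scatter of both neighbours: a 1.8-fold lower number from compound 1 to compound 3 (0.25 log units; within the scatter) and a 1.2-fold higher number from compound 2 to compound 3 (0.08 log units; within the scatter), so the three numbers are not separated by anything the assay can resolve.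

The next compound, compound 4 `Cc1ccc(NC(=O)Cn2c(N)nc(Cc3ccccc3)c2-c2ccccc2Br)cc1`, differs from compound 3 in one place: phenyl in place of hexyl on a saturated chain carbon bound to an aromatic carbon. Of the two measured steps, neither touches this position. The step from compound 1 to compound 3 changes a substituent on the anilide ring, and the step from compound 2 to compound 3 lengthens the saturated chain at its far end; both stayed within the scatter. Among the measured compounds shown here, the hexyl-to-phenyl exchange on the chain carbon bound to the aromatic carbon is therefore untested in this set, and nothing among the measured compounds argues for a step beyond the scatter in either direction in this assay.

Compound 4 is accordingly expected to give about 5000 nM, with a range of 1500 nM to 16000 nM in this assay. The step this estimate implies is a 1.0-fold lower number from compound 3 to compound 4 (0.02 log units; within the scatter), expected to stay within the scatter of the measured values.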

Compound 4, half-maximal inhibitory concentration: 2000 nM
The estimate for compound 4 lay 2.5-fold (0.40 log units) above the measured number, and the stated range covers the measured number.
By their numbers in this assay, from the lowest: compound 4; then compounds 2, 3 and 1 (each within the scatter of the next, the first and the last beyond it).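

In this assay, among the compounds shown here, the saturated chain carbon bound to an aromatic carbon is the first place where a single exchange gives a step beyond the scatter, though a modest one: phenyl in place of hexyl gives (a 2.6-fold lower number from compound 3 to compound 4 (0.41 log units; beyond the scatter)) and phenyl in place of butyl gives (a 2.2-fold lower number from compound 2 to compound 4 (0.33 log units; beyond the scatter)). Both steps run the same way from two different chains, whereas ethyl in place of hydrogen further along the chain stays within the scatter (a 1.2-fold higher number from compound 2 to compound 3 (0.08 log units; within the scatter)), so in these compounds the identity of the group at this place matters more than the chain length alone. No measurement shown here bears on why the phenyl compound gives the lower number.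

From the compounds shown here alone, it remains open whether the aromatic ring itself is required, which a cyclohexyl in place of the phenyl would address, and whether a pyridyl or a phenyl carrying a fluorine or a methoxy group would follow the same direction. Also open, going by these compounds, is whether the step holds when the methyl on the anilide ring is replaced by hydrogen, and whether a longer chain ending in phenyl keeps it.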